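Chain-end ring swap in a collagen promoter series

This account rests on a few compounds, and the source may have more. Where it says the series, first, only, none or still open, it means among the compounds named here.

Measured compounds:
compound 1 `CC[N+]1(CCCCCCCOc2cc(C)cc(-n3cc(C(=O)Nc4cc(F)cc(F)c4)c(=O)c4ccc(N(C)C)nc43)c2)CCCC1`: 73.2%
compound 2 `CC[N+]1(CCCCCCCOc2cc(-n3cc(C(=O)Nc4cc(F)cc(F)c4)c(=O)c4ccc(N(C)C)nc43)ccc2C)CCCC1`: 81.4%
compound 3 `Cc1cc(OCCCCCCC[N+](C)(C)C2CCCCC2)cc(-n2cc(C(=O)Nc3cc(F)cc(F)c3)c(=O)c3ccc(N(C)C)nc32)c1`: 89.1%

In an assay on LX2 cells for inhibition of COL1A1 promoter (Homo sapiens), read by a luciferase reporter, with a stated time of 24 h, tested at 50 uM (on this read-out higher numbers stand for a stronger effect at the one concentration tested and lower numbers for a weaker effect), compound 1 gives 73.2%. Compound 3 carries a group of 9 heavy atoms (8 carbon, 1 nitrogen; one six-membered non-aromatic ring of carbon only) in place of a group of 7 heavy atoms (6 carbon, 1 nitrogen; one five-membered non-aromatic ring with 1 hetero atom), on a saturated chain carbon, seven bonds along the chain from an oxygen on an aromatic ring, and the step is a number 15.9 percentage points higher from compound 1 to compound 3 (beyond the scatter). Compound 2 has the same atoms as compound 1 joined differently; the difference between the two cores is not broken down here. In this assay compound 2 gives 81.4%, which sits within the scatter of both compound 1 and compound 3, so no order among these three is claimed.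

Compound 4 `Cc1ccc(-n2cc(C(=O)Nc3cc(F)cc(F)c3)c(=O)c3ccc(N(C)C)nc32)cc1OCCCCCCC[N+](C)(C)C1CCCCC1` is not yet measured. Relative to compound 2 it carries a group of 9 heavy atoms (8 carbon, 1 nitrogen; one six-membered non-aromatic ring of carbon only) in place of a group of 7 heavy atoms (6 carbon, 1 nitrogen; one five-membered non-aromatic ring with 1 hetero atom), on a saturated chain carbon, seven bonds along the chain from an oxygen on an aromatic ring, the same change as from compound 1 to compound 3, at the same place. The step is expected to be a number 8.6 percentage points higher from compound 2 to compound 4 (within the scatter), somewhat smaller than the earlier one because compound 2 already gives 81.4% and the read-out cannot exceed full inhibition. Compound 4 is therefore estimated at 90%, with a likely range from 80% to 97%.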

Compound 4, a percentage reported as inhibition, at one concentration (the size of the read-out at that concentration, not a potency): 61.7%
Estimate against measurement, compound 4: 28.3 percentage points above; the measured number lies below the stated range.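

Carried to the second core, the six-membered carbon ring group in place of the five-membered ring group gives a number 19.7 percentage points lower from compound 2 to compound 4 (beyond the scatter) in this assay. Among these compounds, the change therefore does not transfer between these two cores, even in direction, and a step measured on one core gives no usable estimate for the other: the same change on two cores in this assay, a number 15.9 percentage points higher (beyond the scatter) from compound 1 to compound 3 and a number 19.7 percentage points lower (beyond the scatter) from compound 2 to compound 4, 35.6 percentage points apart, beyond the scatter of two such steps This rests on only two matched pairs, and it does not show which difference between the cores matters, nor does it give a rule for other chain-end groups or a potency ranking, since the read-out comes from one concentration.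

Still open, on these data alone, is whether a piperidine ring or a trimethylammonium group at the chain end would also behave differently on the two cores. Also open, as far as these compounds go, is whether the split between the cores persists with a shorter or longer chain between the aromatic oxygen and the charged nitrogen.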